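Ketone chain branching in a linked bis-aryl series

The source may hold more compounds than are shown below. What is called first, only, known or untested is meant among the compounds shown, and "the series" means these compounds.

Measured compounds:
compound 1 `COc1cc(C(=O)O)ccc1OCCCCOc1ccc(C(=O)C(C)C)c(O)c1C` gives 73.1%
compound 2 `CCCC(=O)c1ccc(OCCCCOc2cccc(C(=O)O)c2C)c(C)c1O` gives 82.4%
compound 3 `Cc1c(OCCCCOc2ccc(C(=O)O)cc2Cl)ccc(C(=O)CC(C)C)c1O` gives 99.5%

All three values come from an assay on HEK293 cells for positive allosteric modulation of metabotropic glutamate receptor 2 (Rattus norvegicus), read by thallium flux, with a stated time of 2.5 min; a higher number here means a larger maximal response, a lower number a smaller maximal response. Compound 2 stands second highest of the three numbers. Its nearest neighbour is compound 1, whose value lies within the usual scatter of compound 2, so no order between these two can be read. Within the data shown here, compound 3 sits beyond the scatter above compound 2; since the two compounds differ in several places at once, the values show only that compound 3 reaches a larger maximal response.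

Compound 4 `Cc1c(OCCCCOc2ccc(C(=O)CC(C)(C)C)c(O)c2C)cccc1C(=O)O` has not yet been measured in this assay. It differs from compound 2 in one place: tert-butyl in place of ethyl on a saturated chain carbon bound to a carbonyl carbon. Among the measured compounds shown here, no pair of measured compounds differs in a single place, so no counted step is available to guide the expectation, and the change is judged from the spread of the three values alone.

The step from compound 2 to compound 4 is expected to be small, a number 2.6 percentage points higher from compound 2 to compound 4 (within the scatter), not clearly beyond the scatter in either direction. Compound 4 is therefore estimated at 85%, with a range from 65% to 102%.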

Compound 4, largest response reached (reported as percent of maximum), in percent of the reference or control that the assay uses: 95.8%
Compound 4: middle estimate off by 10.8 percentage points, on the low side; low and high end bracket the measured number.
By their numbers in this assay, from the lowest: compounds 1 and 2 (each within the scatter of the next); then compounds 4 and 3 (each within the scatter of the next).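

In this assay, among these compounds, tert-butyl in place of ethyl on a saturated chain carbon bound to a carbonyl carbon gives the only single-place comparison in this set, and the step is a number 13.4 percentage points higher from compound 2 to compound 4 (beyond the scatter). This position therefore accepts the branched neopentylcarbonyl chain in place of the propylcarbonyl chain without loss of maximal response, and compound 4 reaches 95.8%, so the chain is a place where a change can move this read-out beyond the scatter. No measurement at hand bears on why the response rises with this change.

On these data alone, it remains open whether the rise goes with the branching itself or with the longer chain, and an unbranched pentyl chain at this place would separate the two. Also open, as far as these compounds go, is whether the same exchange carries over to the core of compound 1 or the core of compound 3, and whether a cyclohexyl group or a chain ending in a hydroxyl group would hold the response at this position.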